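The source may report more compounds than this note shows. Statements on the series, on what has been measured and on what is new or still open speak of the compounds shown alone.

Values in a functional assay on cells (Homo sapiens) for cytotoxicity, read by resazurin assay, with a stated time of 72 h; a lower number here means a stronger inhibitor, a higher number a weaker inhibitor:
- compound 1 `COc1cc(/C=C/C(=O)OCCCCCCO[N+](=O)[O-])ccc1O`: > 50000 nM
- compound 2 `COc1cc(/C=C/C(=O)OCCCO[N+](=O)[O-])ccc1OCCCO[N+](=O)[O-]`: > 50000 nM
- compound 3 `COc1cc(/C=C/C(=O)OCCCO[N+](=O)[O-])ccc1O`: 39400 nM

Compound 1 gives > 50000 nM, which is a limit. Compound 2 gives > 50000 nM, which is also a limit. For the measured compounds named here, compound 3, at 39400 nM, therefore holds the only true number in the set.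

Compound 4 `COc1cc(/C=C/C(=O)OC/C=C/CO[N+](=O)[O-])ccc1O` departs from compound 3 in the ester chain: a group of 7 heavy atoms (3 carbon, 1 nitrogen, 3 oxygen; no ring) in place of a group of 6 heavy atoms (2 carbon, 1 nitrogen, 3 oxygen; no ring), on a saturated chain carbon bound to an oxygen next to a carbonyl group. Going by the values given here, two measured steps bear on this change: an at least 1.2-fold lower number from compound 1 to compound 3 (0.10 log units; that floor lies within the scatter), and an at least 1.2-fold lower number from compound 2 to compound 3 (0.10 log units; that floor lies within the scatter). Both sizes are floors only, and neither is shown to pass the scatter. The first alters the same chain, while the second does not.

Since compound 3 sits at 39400 nM, no step beyond the scatter is expected in this assay, in either direction. Compound 1 and compound 2 share one limit: the limit of > 50000 nM in this assay, at which 2 of the 3 values shown sit. A limit reading for compound 4 is therefore a real possibility.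

The expected result is a 1.1-fold lower number from compound 3 to compound 4 (0.05 log units; within the scatter). For compound 4 the estimate is 35000 nM, with an expected range of 15000 nM to 70000 nM.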

Compound 4, half-maximal inhibitory concentration: 21900 nM
The estimate for compound 4 lay 1.6-fold (0.20 log units) above the measured number, within the range that was stated.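

In this assay, the change in the ester chain, a group of 7 heavy atoms in place of 2-(nitrooxy)ethyl on a saturated chain carbon bound to an oxygen next to a carbonyl group, gives a 1.8-fold lower number from compound 3 to compound 4 (0.26 log units; within the scatter). For the compounds shown here, this is the first step at this position with a full size rather than a floor, and it shows that the chain with its additional double bond outside aromatic rings is accepted with no shift beyond the scatter. Compound 4 reads as a number and not as a limit, so the limit stays with the other two compounds: the limit of > 50000 nM in this assay, at which 2 of the 4 values shown sit.

Because the extra carbon and the double bond enter together, the compounds shown do not separate their contributions. Also open, on these data alone, is how a chain ending in an amine or a carboxylic acid, in place of the nitrooxy group, would read in this assay.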